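This account rests on a few compounds, and the source may have more. Where it says the series, first, only, none or still open, it means among the compounds named here.

Compound 1, `O=c1[nH]cc(S(=O)(=O)Nc2ccccc2-c2cn(-c3cccc(Cl)c3)nn2)c(=O)[nH]1`, was tested in an ADME assay on L02 cells (Homo sapiens) for cytotoxicity, read by MTT assay, with a stated time of 24 h; a higher number here means that more compound is tolerated, a lower number that less compound is tolerated. For compound 1 the result is only a limit of the assay, > 100000 nM. Compound 2, `O=c1[nH]cc(S(=O)(=O)Nc2ccccc2-c2cn(-c3ccc(Cl)cc3)nn2)c(=O)[nH]1`, differs from compound 1 by 4-chlorophenyl in place of 3-chlorophenyl on an aromatic nitrogen. In this assay compound 2 gives 16800 nM. From the compounds shown here alone, that change produced an at least 5.9-fold lower number from compound 1 to compound 2 (0.77 log units; beyond the scatter); how much further it actually reached is unknown, because the limit of > 100000 nM in this assay, at which 1 of the 3 values shown sits, caps the number for compound 1.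

Compound 3, `O=c1[nH]cc(S(=O)(=O)Nc2cccc(-c3cn(-c4cccc(Cl)c4)nn3)c2)c(=O)[nH]1`, carries the same 3-chlorophenyl group as compound 1 on a different core; the difference between the two cores is not broken down here. In this assay compound 3 gives 8330 nM, a value that lies within the scatter of the result for compound 2, so no order between those two can be claimed.

Compound 4, `O=c1[nH]cc(S(=O)(=O)Nc2cccc(-c3cn(-c4ccc(Cl)cc4)nn3)c2)c(=O)[nH]1`, has not yet been measured in this assay. It differs from compound 3 by 4-chlorophenyl in place of 3-chlorophenyl on an aromatic nitrogen, the same kind of change that separates compound 2 from compound 1, with the place described in the same words. If that change acts on the core of compound 3 as it did on the core of compound 1, the number for compound 4 would be expected to be lower than that for compound 3. An expected step of a 2.1-fold lower number from compound 3 to compound 4 (0.32 log units; beyond the scatter) is taken here, smaller than the earlier one, since the earlier step rests on a limit rather than a measured number. Compound 4 is thus estimated at 4000 nM, with a range from 1500 nM to 12000 nM.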

Compound 4, half-maximal cytotoxic concentration: 9860 nM
Compound 4: middle estimate off by 2.5-fold (0.39 log units), on the low side; the measured number falls inside the stated range.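

In this assay, 4-chlorophenyl in place of 3-chlorophenyl on the core of compound 3 gave a 1.2-fold higher number from compound 3 to compound 4 (0.07 log units; within the scatter), so no order can be claimed between these two compounds. The same change therefore did not carry over from the core of compound 1 to the core of compound 3 with the same effect, and the two steps differ by more than their scatter: the same change on two cores in this assay, an at least 5.9-fold lower number (0.77 log units; beyond the scatter) from compound 1 to compound 2 and a 1.2-fold higher number (0.07 log units; within the scatter) from compound 3 to compound 4, at least 7.0-fold (0.84 log units) apart, beyond the scatter of two such steps. From the compounds shown here alone, this shows that, for these two pairs, the outcome of the change was not the same on both cores, but it does not show why, nor how the change would behave on any further core, and the true size of the first step and of the gap stays unknown since the result for compound 1 is only a limit: the limit of > 100000 nM in this assay, at which 1 of the 4 values shown sits.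

The compounds shown leave open whether a plain phenyl, or a phenyl ring bearing fluorine or a methoxy group instead of chlorine, would follow the same course on the two cores. They also leave open whether a change of this kind on a third core would resemble the step seen on the core of compound 1 or the one seen on the core of compound 3.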